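Imine substituent series: alkyl to pyridinylmethyl on the nitrogen

The compounds below may be only part of what the source reports. "The series", "measured", "known", "first", "only" and "open" are said of these compounds alone.

Measured compounds, all in an assay on isolated protein for inhibition of myosin-2 (Bos taurus), read by spectrophotometry, with a stated time of 24 min; on this read-out lower numbers stand for stronger inhibition and higher numbers for weaker inhibition:
compound 1, `C/C(=N\C(C)C)c1c(O)c2ccccc2oc1=O`: >= 100000 nM
compound 2, `CCC(C)/N=C(\C)c1c(O)c2ccccc2oc1=O`: >= 100000 nM
compound 3, `CCCCC/N=C(\C)c1c(O)c2ccccc2oc1=O`: 6700 nM

The value of compound 1 is a limit of this assay, not a number. The value of compound 2 is likewise a limit (the limit of >= 100000 nM in this assay, at which 2 of the 3 values shown sit). Within the data shown here, compound 3 is the only member of the three with a measured number, and both steps into it are large: an at least 14-fold lower number from compound 1 to compound 3 (1.17 log units; beyond the scatter) and an at least 14-fold lower number from compound 2 to compound 3 (1.17 log units; beyond the scatter). The step that the two limits leave unreadable from compound 1 to compound 2 cannot be read.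

Compound 4, `C/C(=N\Cc1cccnc1)c1c(O)c2ccccc2oc1=O`, is not yet measured. It differs from compound 3 by pyridin-3-yl in place of butyl on a saturated chain carbon bound to a double-bonded nitrogen. Among the measured compounds shown here, the two readable steps both run from a branched substituent on the double-bonded nitrogen to pentyl; none of the measured compounds carries a ring there, so the effect of pyridin-3-yl itself is untested. For the measured compounds named here, compound 4 keeps a saturated chain carbon bound to the double-bonded nitrogen, as compound 3 does, which is the shared feature of the only compound with a number. The step of a 1.3-fold higher number from compound 3 to compound 4 (0.13 log units; within the scatter) is therefore expected to stay within the scatter, with the risk that compound 4 falls back toward the limit. Compound 4 is estimated at 9000 nM, in a range of 2000 nM to 100000 nM.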

Compound 4, half-maximal inhibitory concentration: 17000 nM
For compound 4 the middle estimate is 1.9-fold (0.28 log units) below the measured one; low and high end bracket the measured number.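

In this assay, a measured number at this place no longer depends on an open chain: compound 4 carries a six-membered aromatic ring on the saturated chain carbon bound to the double-bonded nitrogen and still gives a number. The exchange of butyl for pyridin-3-yl is not neutral, though (a 2.5-fold higher number from compound 3 to compound 4 (0.40 log units; beyond the scatter)), so the ring is accepted here but does not fully match the butyl of the pentyl chain. Compound 3 and compound 4 share an unbranched carbon on the double-bonded nitrogen, and the branched substituents stay behind the ring compound (an at least 5.8-fold lower number from compound 2 to compound 4 (0.76 log units; beyond the scatter) and an at least 5.8-fold lower number from compound 1 to compound 4 (0.76 log units; beyond the scatter)), with both sizes resting on the limits of compound 1 and compound 2, between which no step can be read: the limit of >= 100000 nM in this assay, at which 2 of the 4 values shown sit.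

As far as these compounds go, whether the ring nitrogen matters stays open, since a benzyl group on the double-bonded nitrogen would separate the ring from that atom, and pyridin-2-yl or pyridin-4-yl would test where it sits. A hexyl chain, or a butyl chain on the same nitrogen, would show whether pentyl lies at the best length for the open-chain substituents.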